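This account rests on a few compounds, and the source may have more. Where it says the series, first, only, none or still open, it means among the compounds named here.

Compound 1 `CCOC(=O)C(=O)C(CC)NC(=O)C(CC(C)C)NC(=O)OCc1ccccc1`, with ethoxy on a carbonyl carbon, gives 300000 nM in a functional assay for inhibition, with Rattus norvegicus as the target, at pH 7.35; on this read-out higher numbers stand for weaker inhibition and lower numbers for stronger inhibition. With butylamino at that carbonyl, compound 2 `CCCCNC(=O)C(=O)C(CC)NC(=O)C(CC(C)C)NC(=O)OCc1ccccc1` gives 35000 nM. With octylamino there, compound 3 `CCCCCCCCNC(=O)C(=O)C(CC)NC(=O)C(CC(C)C)NC(=O)OCc1ccccc1` gives 200000 nM. Two steps fix the standing of compound 3 on these numbers. The first, a 1.5-fold lower number from compound 1 to compound 3 (0.18 log units; within the scatter), shows no separation, while the second, a 5.7-fold higher number from compound 2 to compound 3 (0.76 log units; beyond the scatter), is modest but beyond the scatter.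

Compound 4 `CCC(NC(=O)C(CC(C)C)NC(=O)OCc1ccccc1)C(=O)C(=O)NCc1ccccc1` keeps the shared core and alters only the amide substituent: phenyl in place of heptyl on a saturated chain carbon bound to an amide-type nitrogen. This is phenyl in place of heptyl on a saturated chain carbon bound to an amide-type nitrogen, so octylamino becomes benzylamino. No amide with an aromatic ring has been measured in this set, so the guidance is indirect. The relevant steps are the two modest ones among the carbonyl substituents: an 8.6-fold lower number from compound 1 to compound 2 (0.93 log units; beyond the scatter) and a 5.7-fold higher number from compound 2 to compound 3 (0.76 log units; beyond the scatter). Swapping octylamino for benzylamino is therefore expected to bring a modest fall in this assay, smaller than the full gap that separates the butylamino and octylamino compounds. The expected change is a 2.9-fold lower number from compound 3 to compound 4 (0.46 log units; beyond the scatter). Compound 4 is estimated at 70000 nM, with an expected range of 20000 nM to 200000 nM.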

Compound 4, half-maximal inhibitory concentration: 50000 nM
The estimate for compound 4 lay 1.4-fold (0.15 log units) above the measured number; low and high end bracket the measured number.
By their numbers in this assay, from the lowest: compounds 2 and 4 (each within the scatter of the next); then compounds 3 and 1 (each within the scatter of the next).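

Phenyl in place of heptyl on a saturated chain carbon bound to an amide-type nitrogen gives a 4.0-fold lower number from compound 3 to compound 4 (0.60 log units; beyond the scatter), so in this assay the weak standing of octylamino does not extend to every larger amide substituent at this carbonyl. Benzylamino cannot be told apart from butylamino, with a 1.4-fold higher number from compound 2 to compound 4 (0.15 log units; within the scatter), and it also stands clear of ethoxy, with a 6.0-fold lower number from compound 1 to compound 4 (0.78 log units; beyond the scatter), so two amides now share this gain while octylamino remains the exception, lying within the scatter of ethoxy. The compounds offer no independent measurement that would account for the separation of benzylamino from octylamino.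

The series leaves open where along the chain the loss begins, since hexylamino could side with either butylamino or octylamino. It also leaves open whether the gain depends on the ring itself or on the length of the substituent, a question that phenethylamino, cyclohexylmethylamino or a benzyl ring carrying a methoxy group could address.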